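Acetamido in place of chloro on a spiro-fused cell-growth inhibitor

A few compounds are considered here, and "the series" means these few. Any claim that something is new, unique, unknown or untested is made for them only; others in the source may bear on it.

Measured so far in a functional assay on HCT-116 cells (Homo sapiens) for antiproliferative activity, read by MTT assay, with a stated time of 48 h; a lower number here means a stronger inhibitor, a higher number a weaker inhibitor:
compound 1 `N#CC1=C(N)Oc2c(c3nc4ccccc4nc3c3ccccc23)C12C(=O)N(Cc1cnnn1-c1ccccc1Cl)c1ccccc12` gives > 50000 nM, a limit of the assay.
compound 2 `N#CC1=C(N)Oc2c(c3nc4ccccc4nc3c3ccccc23)C12C(=O)N(Cc1cnnn1-c1ccc(Br)cc1)c1ccccc12` gives > 50000 nM, again a limit.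
compound 3 `N#CC1=C(N)Oc2c(c3nc4ccccc4nc3c3ccccc23)C12C(=O)N(Cc1cnnn1-c1ccc(N)cc1)c1ccccc12` gives 45200 nM.

Compound 1 stands at the limit (the limit of > 50000 nM in this assay, at which 2 of the 3 values shown sit), so only a bound is known for it. Compound 4 `CC(=O)Nc1ccc(-n2nncc2CN2C(=O)C3(C(C#N)=C(N)Oc4c3c3nc5ccccc5nc3c3ccccc43)c3ccccc32)cc1` differs from it by 4-acetamidophenyl in place of 2-chlorophenyl on an aromatic nitrogen. The nearest measured step is an at least 1.1-fold lower number from compound 1 to compound 3 (0.04 log units; that floor lies within the scatter), and a step that the two limits leave unreadable from compound 1 to compound 2. Neither shows a shift beyond the scatter, so no clear change is expected in this assay. The estimate for compound 4 is 50000 nM, within 25000 nM to 100000 nM, which is expected to mean a number no higher from compound 1 to compound 4 (the limit leaves the size open).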

Compound 4, half-maximal inhibitory concentration: > 50000 nM
Compound 4 ended at the assay's limit; the forecaster's own chance of this, stated with the estimate: 60%; the middle value lies on the limit itself.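

Acetyl in place of hydrogen on the amino nitrogen of compound 3 gives an at least 1.1-fold higher number from compound 3 to compound 4 (0.04 log units; that floor lies within the scatter) in this assay. As far as these compounds go, the value of compound 4 is a limit and not a number, so this floor is all that can be said, and the true size of the step remains unknown. The steps to compound 4 from compound 1 and from compound 2 cannot be read, because both ends of each step sit at a limit: the limit of > 50000 nM in this assay, at which 3 of the 4 values shown sit.

From the compounds shown here alone, it remains open whether any group on this phenyl ring can give a clear shift in this assay. A carboxylic acid or a methoxy group in place of the acetamido would test this.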